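This account rests on a few compounds, and the source may have more. Where it says the series, first, only, none or still open, it means among the compounds named here.

Compound 1 `O=C1COc2ccc(-c3cccc(NS(=O)(=O)c4ccc(F)cc4)c3)cc2N1`: 32100 nM
Compound 2 `O=C1COc2ccc(-c3ccc(O)cc3)cc2N1`: > 40000 nM (a limit)

Among the compounds with values here, in a functional assay on A549 cells (Homo sapiens) for antiproliferative activity, read by MTT assay, with a stated time of 72 h (on this read-out higher numbers stand for weaker inhibition and lower numbers for stronger inhibition), compound 1 gives 32100 nM, the only exact number so far, and it marks weak inhibition. Compound 2 is recorded only as a limit, > 40000 nM.

Compound 3 `COc1ccc(N2C(=O)COc3ccc(-c4cccc(NS(=O)(=O)c5ccc(F)cc5)c4)cc32)cc1` keeps the core of compound 1 and changes in one place, with 4-methoxyphenyl in place of hydrogen on an amide-type nitrogen in a ring. Within the data shown here, no pair of measured compounds shows what a change of this kind does, so any forecast here is uncertain. A moderate gain in strength in this assay is expected, although a result within the usual scatter would be no surprise. The expected size of the change is a 4.0-fold lower number from compound 1 to compound 3 (0.60 log units; beyond the scatter). Compound 3 is estimated at 8000 nM, with an expected range from 1500 nM to 35000 nM.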

Compound 3, half-maximal inhibitory concentration: 38200 nM
Compound 3: the middle estimate sits 4.8-fold (0.68 log units) below what was measured; measured number above the stated range.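

In this assay, within the data shown here, this is the first look at a group on the amide-type nitrogen in the ring, and the step is a 1.2-fold higher number from compound 1 to compound 3 (0.08 log units; within the scatter). Replacing the amide hydrogen with 4-methoxyphenyl therefore neither gains nor loses measurable strength, so this one group on this nitrogen leaves the weak inhibition of compound 1 unchanged. Compound 2 is recorded only as a limit, and it shows how close to the end of the reported range this series still sits: the limit of > 40000 nM in this assay, at which 1 of the 3 values shown sits.

One flat step cannot show whether the position tolerates every group or whether 4-methoxyphenyl is simply a neutral case. A small methyl, a short chain ending in an amine or a carboxylic acid on the same nitrogen could still behave differently, and the compounds shown do not settle this.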